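This account rests on a few compounds, and the source may have more. Where it says the series, first, only, none or still open, it means among the compounds named here.

Among the measured compounds shown here, compound 2, with the structure `COc1ccc(C(=O)Nc2ccc3nc(NC(=O)C4CCCCC4)sc3c2)cc1`, stands at the higher of the two numbers measured so far in a functional assay on WI-38 VA13 cells (Homo sapiens) for cytotoxicity; a lower number here means that less compound is needed, a higher number that more compound is needed for the effect: compound 2 gives 4.9 ug/mL, whereas compound 1, the structure `O=C(Nc1ccc2nc(NC(=O)C3CCCCC3)sc2c1)c1ccccc1Cl`, gives 0.025 ug/mL in this assay. For the measured compounds named here, the single measured step is a 200-fold higher number from compound 1 to compound 2 (2.29 log units; beyond the scatter). The change in that step sits on the same carbonyl carbon that is altered again on the way to compound 3.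

Compound 3 has the structure `CCCC(C)C(=O)Nc1ccc2nc(NC(=O)C3CCCCC3)sc2c1`. Its difference from compound 2 is 1-methylbutyl in place of 4-methoxyphenyl on a carbonyl carbon. Going by the values given here, the only step that bears on this change is the one from compound 1 to compound 2, and it was large; but it swapped one aromatic group for another, while the present change removes the aromatic ring altogether, so its size gives no clear direction here. Among the compounds with values here, no measured pair shows an alkyl group at this carbonyl carbon. The author therefore expects a step of a 1.6-fold lower number from compound 2 to compound 3 (0.21 log units; within the scatter) that cannot be fixed in direction with any confidence, and estimates compound 3 at 3 ug/mL in this assay, with a range from 0.3 ug/mL to 30 ug/mL.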

Compound 3, half-maximal effective concentration: 0.14 ug/mL
Compound 3: the middle estimate sits 21-fold (1.33 log units) above what was measured, outside the stated range (below it).
By their numbers in this assay, from the lowest: compound 1; then compound 3; then compound 2.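

In this assay, the step with 1-methylbutyl in place of 4-methoxyphenyl on a carbonyl carbon is a 35-fold lower number from compound 2 to compound 3 (1.54 log units; beyond the scatter), which shows that a low number at this place does not depend on an aromatic ring. The step with the same chain in place of 2-chlorophenyl is a 5.6-fold higher number from compound 1 to compound 3 (0.75 log units; beyond the scatter), so compound 3 falls between the two compounds that carry an aromatic ring, and the presence or absence of a ring alone does not set the order of the three. What the ring carries therefore counts for at least as much here as whether a ring is present, although no measurement shown explains why these groups differ in this way.

The compounds shown leave open whether the branch in 1-methylbutyl matters, which a straight pentyl chain or a cyclohexyl ring on the same carbonyl carbon would test. They also do not separate the contributions of the chlorine and the methoxy group, which an unsubstituted phenyl ring would help to do, and they give no reading for a group such as an amine or a carboxylic acid at this place.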